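The source may report more compounds than this note shows. Statements on the series, on what has been measured and on what is new or still open speak of the compounds shown alone.

Working notes on the series, read in a physicochemical assay for solubility, in phosphate buffer, at pH 6.8 (on this read-out higher numbers stand for higher solubility and lower numbers for lower solubility), throughout. Compound 1 (`CC(C)(C)C(=O)C1=C(O)C(=O)N(c2ccc(-c3ccsc3)cc2)C1c1ccccc1OCCO`) gives > 50000 nM here, a limit and not a number. Among the compounds with values here, compound 2 (`COc1ccccc1C1C(C(=O)C(C)(C)C)=C(O)C(=O)N1c1ccc(-c2ccsc2)cc1`) gives 900 nM as the only true number so far. Compound 3 (`COc1ccccc1C1C(C(=O)C(C)C)=C(O)C(=O)N1c1ccc(-c2ccsc2)cc1`) gives > 50000 nM here, also a limit and not a number, so it sits at the same limit as compound 1.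

Within the data shown here, compound 4 (`CC(C)C(=O)C1=C(O)C(=O)N(c2ccc(-c3ccsc3)cc2)C1c1ccccc1OCCO`) differs from compound 3 by hydroxymethyl in place of hydrogen on a saturated chain carbon bound to an oxygen on an aromatic ring as its one change. That change, read backwards, appears in the step of an at least 55-fold lower number from compound 1 to compound 2 (1.74 log units; beyond the scatter) on the way down. The other large step is an at least 55-fold higher number from compound 2 to compound 3 (1.74 log units; beyond the scatter) for hydrogen in place of methyl. Both sizes are bounds only because of the limit of > 50000 nM in this assay, at which 2 of the 3 values shown sit, at one end of each step.

Compound 4 carries both features that sit on the high side of these steps, so no fall is expected. The expected step is a step that the limit leaves unreadable from compound 3 to compound 4 and it will probably be reported only as a limit. Compound 4 is estimated at 70000 nM with an expected range from 30000 nM to 200000 nM on this read-out.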

Compound 4, solubility: > 50000 nM
Compound 4: a limit, no number (the forecaster's own chance of this, stated with the estimate: 85%); the middle value lies beyond the limit too.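

The steps from compound 3 to compound 4 and from compound 1 to compound 4 cannot be read in this assay: the limit of > 50000 nM in this assay, at which 3 of the 4 values shown sit.

The compounds shown leave open how compound 1, compound 3 and compound 4 stand against one another, and how large the step for hydroxymethyl in place of hydrogen is from compound 3 to compound 4.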